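This account rests on a few compounds, and the source may have more. Where it says the series, first, only, none or still open, it means among the compounds named here.

Measured compounds:
- compound 1, `Nc1nn(Cc2cn(-c3ccc(O)c([N+](=O)[O-])c3)nn2)c2nc(-c3ccccc3)cc(C(F)(F)F)c12`: 36.3 ug/mL in a functional assay on THP-1 cells (Homo sapiens) for cytotoxicity, read by MTT assay, with a stated time of 24 h; on this read-out lower numbers stand for stronger inhibition and higher numbers for weaker inhibition
- compound 2, `Nc1nn(Cc2cn(CC(=O)Nc3ccccc3)nn2)c2nc(-c3ccccc3)cc(C(F)(F)F)c12`: 54.6 ug/mL in this assay

Compound 2 sits within the usual scatter of compound 1; the step of a 1.5-fold higher number from compound 1 to compound 2 (0.18 log units; within the scatter) does not separate them. Compound 3, `Nc1nn(Cc2cn(CC(=O)Nc3ccc(F)cc3)nn2)c2nc(-c3ccccc3)cc(C(F)(F)F)c12`, has not yet been measured in this assay. It differs from compound 2 by fluoro in place of hydrogen on an aromatic carbon, on the phenylcarbamoyl group. Going by the values given here, no measured step bears on a fluoro for hydrogen on an aromatic carbon; the only step measured, a 1.5-fold higher number from compound 1 to compound 2 (0.18 log units; within the scatter), replaces a different group. Without a precedent, no step beyond the scatter is expected, a 1.1-fold lower number from compound 2 to compound 3 (0.04 log units; within the scatter). Compound 3 is estimated at 50 ug/mL in this assay, range 25 ug/mL to 110 ug/mL.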

Compound 3, half-maximal inhibitory concentration: 49.6 ug/mL
Compound 3: middle estimate off by 1.0-fold (0.00 log units), on the high side, and the stated range covers the measured number.
By their numbers in this assay, from the lowest: compounds 1, 3 and 2 (each within the scatter of the next).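

In this assay the fluoro on the phenylcarbamoyl group, para to a large group, does not separate the pair (a 1.1-fold lower number from compound 2 to compound 3 (0.04 log units; within the scatter)). Replacing 4-hydroxy-3-nitrophenyl with ((4-fluorophenyl)carbamoyl)methyl likewise gives no step beyond the scatter (a 1.4-fold higher number from compound 1 to compound 3 (0.14 log units; within the scatter)), so neither change yet marks this part of the structure as sensitive. No supporting data bear on this result.

Going by these compounds, it remains open whether an amine, a carboxylic acid or a longer chain in place of the fluoro would move the number beyond the scatter.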